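A few compounds are considered here, and "the series" means these few. Any claim that something is new, unique, unknown or untested is made for them only; others in the source may bear on it.

Measured in a functional assay on MCF7 cells (Homo sapiens) for inhibition, read by colorimetric assay and MTT assay, with a stated time of 72 h; a lower number here means a stronger inhibitor, a higher number a weaker inhibitor:
- compound 1 `C=CCCCCOc1ccccc1-c1cnc(OCCC=C)n1C`: 8000 nM
- compound 2 `C=CCCCCOc1ccc(F)cc1-c1cnc(OCCC=C)n1C`: 43000 nM

Compound 1 gives 8000 nM, the lower of the two numbers and so the stronger inhibition in this assay. Compound 3 `C=CCCCCOc1ccccc1-c1cnc(OCCOCC=C)n1C` keeps the core of compound 1 and differs only in its chain: allyloxy in place of vinyl on a saturated chain carbon, two bonds along the chain from an oxygen on an aromatic ring. Cut one bond further out, the same difference reads but-3-en-1-yl to 2-(allyloxy)ethyl.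

Among the compounds with values here, only one measured step is available, and it involves a different change: fluoro in place of hydrogen on an aromatic carbon. That step, a 5.4-fold higher number from compound 1 to compound 2 (0.73 log units; beyond the scatter), is modest but beyond the scatter. It does not bear directly on the chain change and gives no firm direction for it, but it does offer a rough idea of the size a single edit can produce in this small set. Within the data shown here, no measured compound carries the new chain. A small step is therefore expected, tentatively towards a higher number and smaller than the measured one. Compound 3 is estimated at 12000 nM, with an expected range of 4000 nM to 35000 nM. The expected change is a 1.5-fold higher number from compound 1 to compound 3 (0.18 log units; within the scatter).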

Compound 3, half-maximal inhibitory concentration: 32000 nM
Compound 3: the middle estimate sits 2.7-fold (0.43 log units) below what was measured, and the stated range covers the measured number.
By their numbers in this assay, from the lowest: compound 1; then compounds 3 and 2 (each within the scatter of the next).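

In this assay, the chain position is shown to respond to change: with allyloxy in place of vinyl on a saturated chain carbon, two bonds along the chain from an oxygen on an aromatic ring, the step is a 4.0-fold higher number from compound 1 to compound 3 (0.60 log units; beyond the scatter), so the result matters here and not only on the aromatic carbon. Among the compounds shown, the two single edits away from compound 1, one on the aromatic carbon and one on this chain, both lead to a higher number, though two edits make only a small sample and compound 1 with its but-3-en-1-yl chain simply stays lowest. The change swaps a group of 2 heavy atoms and no hydrogen-bond acceptor for one of 4 heavy atoms and 1 hydrogen-bond acceptor, but no measurement at hand accounts for the step.

The compounds shown cannot separate the added length from the added ether oxygen, and a longer all-carbon chain in the same place would be needed to tell the two apart. From the compounds shown here alone, how an amine or a carboxylic acid at the end of this chain would read in this assay also stays open.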